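The source may report more compounds than this note shows. Statements on the series, on what has been measured and on what is new or still open speak of the compounds shown alone.

Working notes on the series.

Three compounds share one core and differ only in the pattern of substituents. Compound 1 `CC1CCN(c2c(S(=O)(=O)c3ccc(Cl)c(Cl)c3)cnc3ccc(Cl)cc23)CC1` gives 86% in an assay on isolated protein for displacement of a labelled ligand from metabotropic glutamate receptor 5 (Homo sapiens), with a stated time of 60 min, tested at 1 uM; on this read-out lower numbers stand for less inhibition and higher numbers for more inhibition at the one concentration tested (going by the name of the read-out). Within the data shown here, compound 2 `CC1CCN(c2c(S(=O)(=O)c3cccc(Cl)c3)cnc3ccc(Cl)cc23)CC1` gives 92% in this assay; the single step from compound 1 to compound 2, hydrogen in place of chloro on an aromatic carbon, moves the read-out by a number 6 percentage points higher from compound 1 to compound 2 (within the scatter). Compound 3 `Cc1ccc2ncc(S(=O)(=O)c3ccc(Cl)cc3)c(N3CCC(C)CC3)c2c1` gives 79% in this assay, the lowest of the three numbers: compound 1 sits nearest, a gap within the scatter, while compound 2 lies furthest, a gap beyond the scatter.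

Compound 4 `CC1CCN(c2c(S(=O)(=O)c3ccc(Cl)cc3)cnc3ccc(Cl)cc23)CC1` is not yet measured. It differs from compound 3 by chloro in place of methyl on an aromatic carbon on an aromatic carbon of a six-membered aromatic ring of carbon only, part of a fused or bridged system of two rings.

Among the measured compounds shown here, no measured step changes methyl to chloro, and the only measured step, the one from compound 1 to compound 2, concerns a different ring and stays within the scatter. What can be drawn on is that compound 1 and compound 2, both carrying chloro at this place of the core, score higher than compound 3, which carries methyl there. A modest rise is therefore expected, about a number 7 percentage points higher from compound 3 to compound 4 (within the scatter), though a step within the scatter would not be surprising.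

For compound 4 the expected read-out in this assay is 86%, with a range from 74% to 96%.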

Compound 4, a percentage reported as inhibition, at one concentration (the size of the read-out at that concentration, not a potency): 92%
Estimate against measurement, compound 4: 6 percentage points below, within the range that was stated.
By their numbers in this assay, from the lowest: compounds 3, 1, 2 and 4 (each within the scatter of the next, the first and the last beyond it).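

The methyl to chloro change on an aromatic carbon of the fused system now has its own measured step in this assay with the sulfonyl group held as 4-chlorophenyl: the read-out is a number 13 percentage points higher from compound 3 to compound 4 (beyond the scatter) and this is a direct matched comparison at this place of the shared core. With chloro at this place, the sulfonyl aryl pattern can also be read directly: the read-out shows no change at the digits printed from compound 2 to compound 4 (within the scatter) for 4-chlorophenyl in place of 3-chlorophenyl and a number 6 percentage points higher from compound 1 to compound 4 (within the scatter) for hydrogen in place of chloro, so neither change moves it beyond the scatter. No available measurement accounts for the step from methyl to chloro.

Only methyl and chloro are shown at this place, so how a hydrogen, fluoro, methoxy or nitrile group there would read remains open. Going by these compounds, the read-out comes from one concentration and is not a potency, so any difference in potency between compound 2 and compound 4 also remains open.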